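Dichlorophenyl in place of methoxyphenyl on the shared core

The source may hold more compounds than are shown below. What is called first, only, known or untested is meant among the compounds shown, and "the series" means these compounds.

Compound 1 `COc1cc(-n2cnc3ccc(-c4ccc(C(F)(F)F)cc4)cc32)cc(OC)c1OC` gives 3390 nM in a functional assay on A549 cells (Homo sapiens) for antiproliferative activity, read by MTT assay, with a stated time of 72 h (on this read-out higher numbers stand for weaker inhibition and lower numbers for stronger inhibition), and compound 2 `COc1cc(-n2cnc3ccc(-c4cc(F)ccc4F)cc32)cc(OC)c1OC` gives 7940 nM. For compound 3 `COc1ccc(-c2ccc3ncn(-c4cc(OC)c(OC)c(OC)c4)c3c2)cc1` this assay reports only a limit, > 10000 nM, so compound 3 stands at the ceiling of the numbers shown (the limit of > 10000 nM in this assay, at which 1 of the 3 values shown sits). Compound 4 `COc1cc(-n2cnc3ccc(-c4ccc(Cl)cc4Cl)cc32)cc(OC)c1OC` differs from compound 3 by 2,4-dichlorophenyl in place of 4-methoxyphenyl on an aromatic carbon. Going by the values given here, two measured steps bear on this change: an at least 2.9-fold higher number from compound 1 to compound 3 (0.46 log units; beyond the scatter) and an at least 1.2-fold higher number from compound 2 to compound 3 (0.10 log units; that floor lies within the scatter). Both run toward compound 3, so the move from 4-methoxyphenyl to 2,4-dichlorophenyl is expected to give a lower number, a step of about an at least 2.5-fold lower number from compound 3 to compound 4 (0.39 log units; beyond the scatter). Compound 4 is therefore estimated at 4000 nM, with a range from 1500 nM to 10000 nM.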

Compound 4, half-maximal inhibitory concentration: > 10000 nM
Compound 4 ended at the assay's limit; the forecaster's own chance of this, stated with the estimate: 25%; middle value at least 2.5-fold (0.39 log units) from the limit.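

Compound 4 returns only a limit, > 10000 nM, in this assay, so 2,4-dichlorophenyl at this position joins 4-methoxyphenyl at the ceiling: the limit of > 10000 nM in this assay, at which 2 of the 4 values shown sit.

Replacing 4-(trifluoromethyl)phenyl with 2,4-dichlorophenyl gives an at least 2.9-fold higher number from compound 1 to compound 4 (0.46 log units; beyond the scatter), while replacing 2,5-difluorophenyl gives an at least 1.2-fold higher number from compound 2 to compound 4 (0.10 log units; that floor lies within the scatter); the step between the two limits cannot be read. Going by these compounds alone, of these readable steps, only the one from compound 1 is beyond the scatter.

Still open, on these data alone, is how far compound 3 and compound 4 lie past the limit. Also open, as far as these compounds go, is whether an amine or a carboxylic acid on this phenyl ring would shift the number in this assay.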